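Removing the aroyl group from the ring nitrogen of compound 1

This account rests on a few compounds, and the source may have more. Where it says the series, first, only, none or still open, it means among the compounds named here.

Measured so far:
compound 1 `O=C(Nc1ccccc1O)C1CCc2ccccc2N1C(=O)c1ccc(Cl)cc1` — 19600 nM
compound 2 `O=C(Nc1ccccc1C(F)(F)F)C1CCc2ccccc2N1C(=O)c1ccc(Cl)cc1` — 533 nM

Of the compounds shown here, two have been measured in a functional assay on MDA-MB-231 cells (Homo sapiens) for cytotoxicity, read by sulforhodamine B assay, with a stated time of 72 h; a higher number here means a weaker inhibitor of growth, a lower number a stronger inhibitor of growth. Compound 1 gives 19600 nM, the highest of the two numbers; its nearest neighbour is compound 2 with 533 nM, and the step of a 37-fold lower number from compound 1 to compound 2 (1.57 log units; beyond the scatter) is large. That step concerns only the group on the anilide ring.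

Compound 3 `O=C(Nc1ccccc1O)C1CCc2ccccc2N1` takes the opposite direction and cuts the core down: hydrogen in place of (4-chlorophenyl)carbonyl on a nitrogen on an aromatic ring in a ring. Among the compounds with values here, no measured step touches this position, so the only guide is the size of the molecule that remains after the truncation and the already weak number of compound 1. A loss of that many atoms, including the only aromatic ring on that side of the core, is not something the data show to be tolerated, and a move to a weaker value is therefore expected, with the assay possibly reporting only a limit.

Compound 3 is estimated at 45000 nM, with a likely range from 12000 nM to 150000 nM, corresponding to an expected step of a 2.3-fold higher number from compound 1 to compound 3 (0.36 log units; beyond the scatter).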

Compound 3, concentration for 50% growth inhibition: 5260 nM
Estimate against measurement, compound 3: 8.6-fold (0.93 log units) above; measured number outside the range, below it.
By their numbers in this assay, from the lowest: compound 2; then compound 3; then compound 1.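

In this assay, the (4-chlorophenyl)carbonyl group on this nitrogen proves dispensable for growth inhibition when the anilide ring carries hydroxy: replacing it with hydrogen gives a 3.7-fold lower number from compound 1 to compound 3 (0.57 log units; beyond the scatter). The number therefore falls even though 9 heavy atoms and one six-membered aromatic ring of carbon only leave the molecule, so within this pair the group adds nothing to the read-out and the position tolerates its complete loss. No measurement at hand explains why the smaller compound gives the lower number.

The compounds shown leave open whether the same replacement would also lower the number in compound 2, whose anilide ring carries trifluoromethyl, or whether the result holds only with hydroxy on that ring. They also leave open whether a small acetyl group or a benzyl group on this nitrogen would give a number closer to that of compound 3 or to that of compound 1.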